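The compounds below may be only part of what the source reports. "The series", "measured", "known", "first", "only" and "open" are said of these compounds alone.

Measured in a functional assay on MCF7 cells (Homo sapiens) for inhibition, read by MTT assay, with a stated time of 48 h; on this read-out higher numbers stand for weaker inhibition and lower numbers for stronger inhibition:
- Compound 1 `COc1ccc(/C=N/NC(=O)CSc2nnc(-c3ccncc3)n2-c2ccccc2)cc1`: 23700 nM
- Compound 2 `O=C(CSc1nnc(-c2ccncc2)n1-c1ccccc1)N/N=C/c1ccc(O)cc1`: > 50000 nM, a limit of the assay and not a number
- Compound 3 `O=C(CSc1nnc(-c2ccncc2)n1-c1ccccc1)N/N=C/c1ccc(F)cc1`: 12300 nM

Within the data shown here, only two true numbers exist here, and they lie within the usual scatter of each other: a 1.9-fold lower number from compound 1 to compound 3 (0.28 log units; within the scatter). Compound 4 `O=C(CSc1nnc(-c2ccncc2)n1-c1ccccc1)N/N=C/c1ccccc1O` differs from compound 3 by carrying 2-hydroxyphenyl in place of 4-fluorophenyl on a carbon with a double bond to nitrogen. The nearest guide is compound 2, where hydroxy gave way to fluoro: an at least 4.0-fold lower number from compound 2 to compound 3 (0.60 log units; beyond the scatter). Compound 4 reverses that swap, though its 2-hydroxyphenyl is not the ring of compound 2, so the guide is loose. The expected step is a 2.0-fold higher number from compound 3 to compound 4 (0.31 log units; beyond the scatter), towards weaker inhibition. Compound 4 is expected at about 25000 nM, with an estimated range of 9000 nM to 60000 nM.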

Compound 4, half-maximal inhibitory concentration: 10000 nM
Compound 4: the middle estimate sits 2.5-fold (0.40 log units) above what was measured, and the stated range covers the measured number.
By their numbers in this assay, from the lowest: compounds 4, 3 and 1 (each within the scatter of the next, the first and the last beyond it). At a limit, above all of these: compound 2.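

A hydroxy group on this ring is not weak in itself: with 2-hydroxyphenyl in place of 4-hydroxyphenyl there is an at least 5.0-fold lower number from compound 2 to compound 4 (0.69 log units; beyond the scatter), a step read against a limit of the assay and not a number. Against 4-fluorophenyl, 2-hydroxyphenyl makes no clear difference, with a 1.2-fold lower number from compound 3 to compound 4 (0.09 log units; within the scatter). Against 4-methoxyphenyl there is a 2.4-fold lower number from compound 1 to compound 4 (0.37 log units; beyond the scatter), a modest gain.

From the compounds shown here alone, what the hydroxy group of compound 4 itself contributes stays open. An amine or a carboxylic acid in its place would be the next comparison.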